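A Methyl on the Ring Nitrogen: What to Expect

The source may hold more compounds than are shown below. What is called first, only, known or untested is meant among the compounds shown, and "the series" means these compounds.

Three close relatives of one shared core have been tested in an assay on isolated protein for inhibition of ribosomal protein S6 kinase alpha-1 (Homo sapiens), read by mobility shift assay, tested at 30 uM; on this read-out lower numbers stand for less inhibition and higher numbers for more inhibition at the one concentration tested (going by the name of the read-out). Compound 1 `Nc1n[nH]c2cc(-c3ccncc3)[nH]c(=O)c12` gives 22%, compound 2 `COc1cccc(-c2cc3[nH]nc(N)c3c(=O)[nH]2)c1` gives 20%, and compound 3 `CN1CCN(c2ccc(-c3cc4[nH]nc(N)c4c(=O)[nH]3)cc2)CC1` gives 26%. Compound 2 thus stands within the usual scatter of both of its relatives; the three numbers cannot be told apart, and all three point to modest inhibition at the single concentration tested. Compound 4 `COc1cccc(-c2cc3c(c(N)nn3C)c(=O)[nH]2)c1` has not been measured yet. It differs from compound 2 in one place: methyl in place of hydrogen on an aromatic nitrogen. Within the data shown here, no measured pair shows a change of this kind, so the expected step of a number 5 percentage points lower from compound 2 to compound 4 (within the scatter) is none beyond the scatter, with a slight drop as the more likely side. Compound 4 is therefore estimated at 15%, in a range from 0% to 35%.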

Compound 4, a percentage reported as inhibition, at one concentration (the size of the read-out at that concentration, not a potency): 22%
Estimate against measurement, compound 4: 7 percentage points below; the measured number falls inside the stated range.
By their numbers in this assay, from the lowest: compounds 2, 1, 4 and 3 (each within the scatter of the next).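

In this assay, among these compounds, replacing hydrogen with methyl on this aromatic nitrogen gives a number 2 percentage points higher from compound 2 to compound 4 (within the scatter), the first direct reading at this position. At this single concentration, the modest inhibition seen with compound 2 therefore does not depend measurably on keeping that hydrogen. No available evidence explains the result. Still open, as far as these compounds go, is how a larger group on this nitrogen, such as ethyl, benzyl or a longer chain ending in an amine, would read. Also open, from the compounds shown here alone, is whether the same methyl would give a similar result on compound 1 or compound 3.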